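Aryl-oxadiazole thioether series: cytotoxicity notes toward compound 4

The compounds below may be only part of what the source reports. "The series", "measured", "known", "first", "only" and "open" are said of these compounds alone.

Measured so far:
compound 1, `COC(=O)c1ccc(-c2nnc(SC3=CS(=O)(=O)c4ccccc43)o2)cc1`, 4000 nM in an ADME assay on HEK293 cells (Homo sapiens) for cytotoxicity, read by fluorescence and resazurin assay, with a stated time of 24 h; a higher number here means that more compound is tolerated, a lower number that less compound is tolerated
compound 2, `CC(=O)Nc1ccc(-c2nnc(SC3=CS(=O)(=O)c4ccccc43)o2)cc1`, 4000 nM
compound 3, `COc1cccc(-c2nnc(SC3=CS(=O)(=O)c4ccccc43)o2)c1`, 3000 nM

The three compounds share one core and differ only in the aromatic group attached to it. Compound 3 gives the lowest of the three numbers, yet the gap to compound 1 and the gap to compound 2 are both within the scatter, so no order among the three can be claimed.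

Going by the values given here, the only measured single-point step is no change at the digits printed from compound 1 to compound 2 (within the scatter); a swap of one aryl substituent for another leaves the read-out unchanged within the scatter.

Compound 4, `O=S1(=O)C=C(Sc2nnc(-c3ccccn3)o2)c2ccccc21`, is the next step from compound 3. The change is pyridin-2-yl in place of 3-methoxyphenyl on an aromatic carbon. Among the compounds with values here, no measured step covers the exchange of the whole aryl ring for pyridin-2-yl; the one step available, on a substituent only, was flat. For compound 4 a step of a 1.2-fold higher number from compound 3 to compound 4 (0.07 log units; within the scatter) is therefore expected, that is none beyond the scatter. Compound 4 is expected to give 3500 nM, with a range from 1500 nM to 8000 nM.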

Compound 4, half-maximal cytotoxic concentration: 5000 nM
Beside the measured number, compound 4's estimate is 1.4-fold (0.15 log units) below it, within the range that was stated.
By their numbers in this assay, from the lowest: compounds 3, 1, 2 and 4 (each within the scatter of the next).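

In this assay, the exchange of 3-methoxyphenyl for pyridin-2-yl, on an aromatic carbon of a five-membered aromatic ring with 2 nitrogen and 1 oxygen, gives a 1.7-fold higher number from compound 3 to compound 4 (0.22 log units; within the scatter), so replacing a whole aromatic ring at this position leaves the read-out within the scatter. The earlier step covered only a substituent on the aryl ring, whereas this one shows, for this pair, that a six-membered aromatic ring with a ring hetero atom can stand in place of one of carbon only without a change beyond the scatter. Nothing available on these compounds bears on why the read-out stays flat across this exchange.

On these data alone, all four compounds carry a six-membered aromatic ring at this position, so it remains open whether a group of another kind there, such as a saturated ring, an aliphatic amine or a carboxylic acid, would leave the read-out within the scatter. Also open, as far as these compounds go, is whether pyridin-3-yl or pyridin-4-yl would match pyridin-2-yl, and whether a change to the shared core would move the read-out when the aryl exchanges do not.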